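The source may hold more compounds than are shown below. What is called first, only, known or untested is meant among the compounds shown, and "the series" means these compounds.

Compound 1 `CC(=O)OC(C)n1cnc2c(Cl)nc(N)nc21` and compound 2 `CC(=O)OC(C)n1cnc2c(Cl)nc(I)nc21` share the same core and differ in a single group on it. In a functional assay on WI-38 cells (Homo sapiens) for inhibition (on this read-out lower numbers stand for stronger inhibition and higher numbers for weaker inhibition), compound 1 gives only a limit, > 500000 nM. In this assay compound 2 gives 14100 nM. For the measured compounds named here, the one change measured so far is an at least 35-fold lower number from compound 1 to compound 2 (1.54 log units; beyond the scatter), and it rests on the limit of > 500000 nM in this assay, at which 1 of the 2 values shown sits, rather than on two actual numbers. Going by the values given here, compound 2 therefore holds the only number in this assay; the other value is a limit. Compound 3 `CC(=O)OC(C)n1cnc2c(Cl)nc(F)nc21` has not yet been measured and differs from compound 2 by fluoro in place of iodo on an aromatic carbon. The measured step compared amino with iodo and does not compare iodo with fluoro, so the direction of the change in this assay cannot be read from it, and only a moderate shift is expected. Compound 3 is expected to give 40000 nM, with a range from 8000 nM to 250000 nM, which would mean an expected step of a 2.8-fold higher number from compound 2 to compound 3 (0.45 log units; beyond the scatter).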

Compound 3, half-maximal inhibitory concentration: 100000 nM
For compound 3 the middle estimate is 2.5-fold (0.40 log units) below the measured one; the range from low to high includes it.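

At this position, on an aromatic carbon between two ring nitrogen atoms, exchanging one single-atom group for another is enough to shift the result in this assay: there is a 7.1-fold higher number from compound 2 to compound 3 (0.85 log units; beyond the scatter). Fluoro still stays on the lower side of amino, with an at least 5.0-fold lower number from compound 1 to compound 3 (0.69 log units; beyond the scatter), so the three groups now fall in the order iodo, fluoro, amino from lowest number to highest. As far as these compounds go, the true size of that second step remains unknown, and it rests on a limit rather than on two actual numbers: the limit of > 500000 nM in this assay, at which 1 of the 3 values shown sits.

The compounds shown leave open where bromo would fall in this order, and whether it would lie between fluoro and iodo. They also leave open what a methoxy group or a longer carbon chain would do at this position.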